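The compounds below may be only part of what the source reports. "The series", "measured", "known", "first", "only" and "open" are said of these compounds alone.

Measured so far in a functional assay on MDA-MB-231 cells (Homo sapiens) for cytotoxicity, read by neutral red uptake, with a stated time of 72 h; on this read-out higher numbers stand for weaker inhibition and lower numbers for stronger inhibition:

- Compound 1, `CCCCCNc1nc(SCC)nc2ncccc12`, gives 1300 nM.
- Compound 2, `CCCCCCCNc1nc(SCC)nc2ncccc12`, gives 2600 nM.

Compound 1 stands lowest of the two numbers; its nearest neighbour is compound 2, and the step of a 2.0-fold higher number from compound 1 to compound 2 (0.30 log units; within the scatter) lies within the scatter, so the two compounds cannot be told apart on this read-out.

Compound 3, `CCCCCNc1nc(NCCCCC)c2cccnc2n1`, has not yet been measured. It differs from compound 1 by pentylamino in place of ethylsulfanyl on an aromatic carbon.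

For the measured compounds named here, only one measured step is available, and it concerns a different place on the molecule: it lengthens the chain on the pentylamino group rather than touching the ethylsulfanyl group. Going by the values given here, no measured step therefore bears directly on the change from compound 1 to compound 3. Among the compounds with values here, the one step that exists stayed within the scatter, and nothing in the data points to a large movement in either direction. The expectation for compound 3 is accordingly a step of a 1.2-fold higher number from compound 1 to compound 3 (0.06 log units; within the scatter), not beyond the scatter, with a wide range to reflect the missing evidence. Compound 3 is estimated at 1500 nM, between 400 nM and 6000 nM.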

Compound 3, half-maximal inhibitory concentration: 1200 nM
The estimate for compound 3 lay 1.3-fold (0.10 log units) above the measured number, and the stated range covers the measured number.
By their numbers in this assay, from the lowest: compounds 3, 1 and 2 (each within the scatter of the next, the first and the last beyond it).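

In this assay, the exchange on the aromatic carbon between two ring nitrogen atoms gives a 1.1-fold lower number from compound 1 to compound 3 (0.03 log units; within the scatter), so compound 1 and compound 3 cannot be told apart on this read-out. This is the only change shown at this place, and it shows that the number stays within the scatter even though pentylamino brings six heavy atoms where ethylsulfanyl has three, with nitrogen in place of sulfur and a hydrogen-bond donor where ethylsulfanyl has none. Nothing measured here offers an explanation for this result.

Because the group's size, its linking atom and its donor all change together in this one step, the compounds shown cannot separate what each contributes, and an ethylamino group, which would keep the ethyl chain while exchanging only the sulfur for nitrogen, would be the closest test of that. As far as these compounds go, it also remains open whether a carboxylic acid, a ring-bearing amine such as morpholine or a longer chain on this same carbon would move the number beyond the scatter.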